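The compounds below may be only part of what the source reports. "The series", "measured", "known", "first", "only" and "open" are said of these compounds alone.

Three compounds share one core and differ only in the aryl group attached to the saturated chain carbon bound to an oxygen on an aromatic ring. Compound 1 `Cc1ccc(NC(=O)NC(=O)c2ccc(OCc3cccc(Cl)c3)cc2)cc1-c1nc2ccccc2[nH]1` gives 15400 nM in a functional assay on HT-29 cells (Homo sapiens) for inhibition, read by MTT assay, with a stated time of 48 h; on this read-out higher numbers stand for weaker inhibition and lower numbers for stronger inhibition. Compound 2 `Cc1ccc(NC(=O)NC(=O)c2ccc(OCc3ccc(C(F)(F)F)cc3)cc2)cc1-c1nc2ccccc2[nH]1` gives 7830 nM in this assay, and the step of a 2.0-fold lower number from compound 1 to compound 2 (0.29 log units; within the scatter) does not separate the two. Compound 3 `Cc1ccc(NC(=O)NC(=O)c2ccc(OCc3ccccc3F)cc2)cc1-c1nc2ccccc2[nH]1` gives 760 nM in this assay, the lowest of the three numbers, set apart from both neighbours by the steps of a 20-fold lower number from compound 1 to compound 3 (1.31 log units; beyond the scatter) and a 10-fold lower number from compound 2 to compound 3 (1.01 log units; beyond the scatter).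

Compound 4 `Cc1ccc(COc2ccc(C(=O)NC(=O)Nc3ccc(C)c(-c4nc5ccccc5[nH]4)c3)cc2)cc1` is not yet measured. Its change from compound 3 is 4-methylphenyl in place of 2-fluorophenyl on a saturated chain carbon bound to an oxygen on an aromatic ring. Among the measured compounds shown here, no measured step covers exactly this exchange. What the measured compounds show is that the 2-fluorophenyl of compound 3 stands alone as the strong member, while the 3-chlorophenyl of compound 1 and the 4-(trifluoromethyl)phenyl of compound 2 both sit far weaker, as the steps of a 20-fold lower number from compound 1 to compound 3 (1.31 log units; beyond the scatter) and a 10-fold lower number from compound 2 to compound 3 (1.01 log units; beyond the scatter) record. Compound 4 carries 4-methylphenyl, a group unlike the 2-fluorophenyl of compound 3, so its number in this assay is expected to move back toward the range of compound 1 and compound 2, and the step of a 7.9-fold higher number from compound 3 to compound 4 (0.90 log units; beyond the scatter) is estimated to be a large rise. Compound 4 is therefore expected to give 6000 nM in this assay, within a range from 1500 nM to 25000 nM.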

Compound 4, half-maximal inhibitory concentration: 5110 nM
Compound 4: middle estimate off by 1.2-fold (0.07 log units), on the high side, and the stated range covers the measured number.
By their numbers in this assay, from the lowest: compound 3; then compounds 4, 2 and 1 (each within the scatter of the next, the first and the last beyond it).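

Replacing the 2-fluorophenyl group is costly here too: in this assay the step of a 6.7-fold higher number from compound 3 to compound 4 (0.83 log units; beyond the scatter) lies beyond the scatter, so compound 3 now stands apart from three other aryl groups on the saturated chain carbon bound to an oxygen on an aromatic ring. Among the compounds shown here, the step of a 1.5-fold lower number from compound 2 to compound 4 (0.19 log units; within the scatter) lies within the scatter, which gives the first direct exchange on the aromatic carbon of this aryl group and shows that methyl in place of trifluoromethyl does not separate the two compounds in this assay. The step of a 3.0-fold lower number from compound 1 to compound 4 (0.48 log units; beyond the scatter) lies beyond the scatter even though compound 1 and compound 2 are not separated, so the three compounds with weaker numbers do not form one uniform level, and compound 4 can be told apart from compound 1 only.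

The compounds shown leave open whether the low number of compound 3 depends on the fluorine itself or on where it sits, a question that 4-fluorophenyl, 2-chlorophenyl, 2-methylphenyl or unsubstituted phenyl at this position would address. No measurement available here accounts for the difference between 2-fluorophenyl and 4-methylphenyl.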